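The source may hold more compounds than are shown below. What is called first, only, known or untested is meant among the compounds shown, and "the series" means these compounds.

Measured compounds:
compound 1, `Cc1cc(C(N)=O)nn1Cc1cc(Cl)ccc1OCc1ccccc1`, 126 nM
compound 2, `Cc1cc(NC(=O)C(C)C)nn1Cc1cc(Cl)ccc1OCc1ccccc1`, 25.1 nM
compound 3, `Cc1cc(NC(=O)OCc2ccccn2)nn1Cc1cc(Cl)ccc1OCc1ccccc1`, 79.4 nM

All three were tested in an assay on CHO-K1 cells for displacement of a labelled ligand from prostaglandin E2 receptor EP1 subtype (Homo sapiens); a higher number here means a weaker inhibitor, a lower number a stronger inhibitor. Compound 3 sits second highest of the three numbers: compound 1 lies closest, and the gap a 1.6-fold lower number from compound 1 to compound 3 (0.20 log units; within the scatter) is within the scatter, while compound 2 lies furthest, the step of a 3.2-fold higher number from compound 2 to compound 3 (0.50 log units; beyond the scatter) being beyond the scatter.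

Compound 4, `CCOC(=O)Nc1cc(C)n(Cc2cc(Cl)ccc2OCc2ccccc2)n1`, has not yet been measured. It differs from compound 3 in one place: methyl in place of pyridin-2-yl on a saturated chain carbon bound to an oxygen next to a carbonyl group. Among the measured compounds shown here, only one measured step touches the same part of the molecule, the group attached to the carbonyl carbon: a 3.2-fold higher number from compound 2 to compound 3 (0.50 log units; beyond the scatter). That step exchanged isopropyl for (pyridin-2-yl)methoxy and gave a modest rise in the number. For the measured compounds named here, no measured pair shows a pyridin-2-yl being replaced by methyl, so the direct effect of this change is not covered by the data. Trimming the group back to a small alkyl might move the number back toward that of compound 2, yet the oxygen next to the carbonyl group stays in place, so the change is smaller than the one from compound 2 to compound 3. The expectation for the step of a 1.3-fold lower number from compound 3 to compound 4 (0.12 log units; within the scatter) is therefore a small shift, likely within the scatter. Compound 4 is estimated at 60 nM, with a range from 20 nM to 200 nM.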

Compound 4, half-maximal inhibitory concentration: 79.4 nM
For compound 4 the middle estimate is 1.3-fold (0.12 log units) below the measured one; measured number inside the range.
By their numbers in this assay, from the lowest: compound 2; then compounds 3, 4 and 1 (each within the scatter of the next).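

In this assay, the pyridin-2-yl, a six-membered aromatic ring, can give way to a plain methyl on a saturated chain carbon bound to an oxygen next to a carbonyl group with no change at the digits printed from compound 3 to compound 4 (within the scatter), so for these two compounds the ring adds nothing that this read-out can detect. The other two steps fit that picture: a 3.2-fold higher number from compound 2 to compound 4 (0.50 log units; beyond the scatter) is the same size as a 3.2-fold higher number from compound 2 to compound 3 (0.50 log units; beyond the scatter), so ethoxy and (pyridin-2-yl)methoxy stand in the same relation to isopropyl on a carbonyl carbon, while a 1.6-fold lower number from compound 1 to compound 4 (0.20 log units; within the scatter) stays as close to the carbamoyl compound as a 1.6-fold lower number from compound 1 to compound 3 (0.20 log units; within the scatter). Nothing available explains why the large change in the group leaves the number as it is.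

The compounds shown leave open whether this tolerance extends to a longer chain such as butoxy, to a phenyl ring in place of the pyridin-2-yl, or to a chain ending in an amine or a carboxylic acid. They also leave open whether a methylamino group on the carbonyl carbon would behave like ethoxy or like isopropyl.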